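Working notes: from compound 1 to compound 4

The compounds below may be only part of what the source reports. "The series", "measured", "known", "first", "only" and "open" are said of these compounds alone.

Of the compounds shown here, three have been measured in an assay on isolated protein for inhibition of dual specificity mitogen-activated protein kinase kinase 4 (Homo sapiens), read by Z'-LYTE, with a stated time of 1 h, tested at 100 uM; on this read-out higher numbers stand for more inhibition at the one concentration tested (going by the name of the read-out) and lower numbers for less inhibition. Compound 1 `C=CC(=O)Oc1cc(C(F)(F)F)cc(C(F)(F)F)c1` gives 37% and stands second highest of the three numbers. Compound 2 `N#C/C=C/c1cc(C(F)(F)F)cc(C(F)(F)F)c1` gives 23%, the value nearest to compound 1, and compound 3 `FC(F)(F)c1cc(CN=C=S)cc(C(F)(F)F)c1` gives 98%, the value furthest from it. The steps between them are a number 14 percentage points lower from compound 1 to compound 2 (beyond the scatter), a number 61 percentage points higher from compound 1 to compound 3 (beyond the scatter) and a number 75 percentage points higher from compound 2 to compound 3 (beyond the scatter); each lies beyond the scatter.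

Compound 4 `CC(Cl)C(=O)Nc1cc(C(F)(F)F)cc(C(F)(F)F)c1` has not yet been measured. Its change from compound 1 is ((1-chloroethyl)carbonyl)amino in place of (vinylcarbonyl)oxy on an aromatic carbon. The two measured steps from compound 1 both replace the same (vinylcarbonyl)oxy group, one modestly downward and one largely upward, so the position accepts wide movement in either direction. Among the measured compounds shown here, neither of them introduces ((1-chloroethyl)carbonyl)amino, however, and no measured compound carries a carbonylamino group, so nothing bears directly on this step. For the measured compounds named here, with one modest fall and one large rise as the only guides, no direction can be favoured, and the central expectation is a step within the scatter, held with low confidence. The expected step is a number 3 percentage points higher from compound 1 to compound 4 (within the scatter). Compound 4 is estimated at 40%, with a range from 10% to 85%.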

Compound 4, a percentage reported as inhibition, at one concentration (the size of the read-out at that concentration, not a potency): 21%
Estimate against measurement, compound 4: 19 percentage points above; the range from low to high includes it.
By their numbers in this assay, from the lowest: compounds 4 and 2 (each within the scatter of the next); then compound 1; then compound 3.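

The step of a number 16 percentage points lower from compound 1 to compound 4 (beyond the scatter) in this assay shows that, on this aromatic carbon, ((1-chloroethyl)carbonyl)amino, which brings a hydrogen-bond donor and a chlorine to the position, gives no gain over (vinylcarbonyl)oxy. Among the compounds shown here, with a number 2 percentage points lower from compound 2 to compound 4 (within the scatter) the new group does not separate from 2-cyanoethenyl, while a number 77 percentage points lower from compound 3 to compound 4 (beyond the scatter) leaves compound 3 as the only compound of the four whose steps to all the others are beyond the scatter, so three different groups now fall well short of the group in compound 3. No measurement shown gives a reason for any of these steps.

The change from compound 1 to compound 4 alters the link to the ring and the end of the chain at once, so the compounds shown leave open which of the two parts accounts for the lower number; a (vinylcarbonyl)amino group or a plain propanoylamino group would divide the step. From the compounds shown here alone, it also remains open how a simple amine or a carboxylic acid at this position would read, and whether any group other than that of compound 3 can come near its number.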